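Chloro on the methyl compound: expected step

The source may report more compounds than this note shows. Statements on the series, on what has been measured and on what is new or still open speak of the compounds shown alone.

Measured in a functional assay on HT-29 cells (Homo sapiens) for cytotoxicity, read by MTT assay, with a stated time of 6 days; a higher number here means a weaker inhibitor, a lower number a stronger inhibitor:
compound 1 `Cc1ccc2c(c1)OCC(=O)N2Cc1cn(Cc2ccccc2)nn1` gives 54900 nM
compound 2 `COc1ccc2c(c1)OCC(=O)N2Cc1cn(Cc2ccccc2)nn1` gives 9300 nM

Compound 1 holds the higher of the two numbers. Compound 3 `Cc1cc2c(cc1Cl)N(Cc1cn(Cc3ccccc3)nn1)C(=O)CO2` differs from it by chloro in place of hydrogen on an aromatic carbon and carries chloro in place of hydrogen on an aromatic carbon, ortho to a methyl group. Among the measured compounds shown here, no chloro step has been measured. For the measured compounds named here, the only measured step, a 5.9-fold lower number from compound 1 to compound 2 (0.77 log units; beyond the scatter), is a different change, methoxy in place of methyl on an aromatic carbon, and bears only indirectly. A modest move to a lower number in this assay is therefore expected, though the direction is uncertain. The expected step is a 2.2-fold lower number from compound 1 to compound 3 (0.34 log units; beyond the scatter) in size. Compound 3 is estimated at 25000 nM (expected range 7000 nM to 70000 nM) for now.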

Compound 3, half-maximal inhibitory concentration: 19600 nM
For compound 3 the middle estimate is 1.3-fold (0.11 log units) above the measured one; the measured number falls inside the stated range.
By their numbers in this assay, from the lowest: compound 2; then compound 3; then compound 1.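

In this assay, chloro in place of hydrogen on an aromatic carbon, ortho to a methyl group, gives a 2.8-fold lower number from compound 1 to compound 3 (0.45 log units; beyond the scatter) with the methyl group kept. This ring carbon therefore tolerates a chloro substituent, and a change here, not only at the methyl carbon, moves the number lower. Nothing available here accounts for the size of this step.

The compounds shown leave open whether bromo or an amine on this carbon would move the number in the same way. As far as these compounds go, whether chloro gives a similar step on the core of compound 2 also remains open.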